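Hydroxymethyl in place of methyl: a stability estimate

The compounds below may be only part of what the source reports. "The series", "measured", "known", "first", "only" and "open" are said of these compounds alone.

Measured so far in an ADME assay on microsomes from liver (Homo sapiens) for metabolic stability, with a stated time of 10 min; a higher number here means that more of the compound is left, a lower number that less of the compound is left
- compound 1 `O=C(O)C12CCC(C(=O)N3CC[C@](c4ccc(C(F)(C(F)(F)F)C(F)(F)F)cc4)(S(=O)(=O)c4ccc(F)cc4)C3)(CC1)OC2` gives 90%
- compound 2 `CC1(C(=O)N2CC[C@](c3ccc(C(F)(C(F)(F)F)C(F)(F)F)cc3)(S(=O)(=O)c3ccc(F)cc3)C2)CCS(=O)(=O)CC1` gives "not determined" (no result reported)

Compound 2 has no place on this scale, since in this assay compound 2 stands as "not determined" (no result reported) and offers no number to start from. Among the measured compounds shown here, the only number in this small set belongs to compound 1, at 90% in the same read-out.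

The next structure to be tested is compound 3 `O=C(N1CC[C@](c2ccc(C(F)(C(F)(F)F)C(F)(F)F)cc2)(S(=O)(=O)c2ccc(F)cc2)C1)C1(CO)CCS(=O)(=O)CC1`. The change (hydroxy in place of hydrogen on a saturated chain carbon bound to a saturated ring carbon) puts hydroxy in place of hydrogen on a saturated chain carbon bound to a saturated ring carbon, so that methyl becomes hydroxymethyl.

For the measured compounds named here, no step between measured compounds exists to size this change, and the data cannot show its effect directly. Taking compound 1 (90%) as the sole anchor, no difference beyond the usual scatter is expected in this assay, and no direction is favoured. With a single anchor, the expected range stays wide, mostly on the low side. For compound 3 the estimated value is 85% (expected range 65% to 98%).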

Compound 3, percent of the compound remaining: 75%
The estimate for compound 3 lay 10 percentage points above the measured number, and the stated range covers the measured number.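

In this assay, among the compounds shown here, compound 3 gives 75%, which is the first number for a group of the 1,1-dioxothian type on this carbonyl carbon, here 4-(hydroxymethyl)-1,1-dioxothian-4-yl. Replacing the group of 11 heavy atoms, with its two six-membered non-aromatic rings, by this group of 10 heavy atoms with one such ring gives a number 15 percentage points lower from compound 1 to compound 3 (beyond the scatter), so the group held on this carbonyl carbon does register in this read-out, although the shared core stays the same and the compound remains well measurable. Nothing at hand explains this step, and the result therefore stands as an observation only.

On these data alone, the step from methyl to hydroxymethyl itself cannot be read, as compound 2 has no number, and so the share of the hydroxy group in the difference between the two measured compounds remains unknown. Also open is how this read-out would respond if aminomethyl, methoxymethyl or a longer chain such as 2-hydroxyethyl stood in place of hydroxymethyl on the same 1,1-dioxothian group, as the compounds shown offer only one measured member of that type.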